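Replacing the Triflyl Sulfonamide with a Methylated Mesyl Amide

The source may hold more compounds than are shown below. What is called first, only, known or untested is meant among the compounds shown, and "the series" means these compounds.

This account concerns three compounds that share the same core. Compound 1 `COc1cc(C(C)C(=O)NCc2ccc(C(F)(F)F)nc2N2CCC(C)CC2)cc(OC)c1NS(C)(=O)=O` is the reference point: in an assay on cells for antagonist activity at transient receptor potential cation channel subfamily V member 1 (Homo sapiens), read by FLIPR and calcium flux, with a stated time of 15 min (on this read-out lower numbers stand for stronger inhibition and higher numbers for weaker inhibition), compound 1 gives 1.6 nM. Compound 2 `CC1CCN(c2nc(C(F)(F)F)ccc2CNC(=O)C(C)c2ccc(NS(=O)(=O)C(F)(F)F)c(F)c2)CC1`, which carries a fluoro group and a ((trifluoromethyl)sulfonyl)amino group on its aromatic ring, was reported in this assay only as "not active" (no number reported), so no number is available for compound 2 and its position cannot be fixed on the scale. Compound 3 `CC1CCN(c2nc(C(F)(F)F)ccc2CNC(=O)C(C)c2ccc(N(C)S(C)(=O)=O)c(F)c2)CC1` differs from compound 2 in one place: methyl(methylsulfonyl)amino in place of ((trifluoromethyl)sulfonyl)amino on an aromatic carbon. Within the data shown here, since no measured pair shows this change, no size of step can be taken from the data; the change from compound 2 to compound 3 is expected to move activity in the stronger direction beyond the scatter, because compound 2 is "not active" (no number reported) while compound 1, which also bears a methylsulfonyl group, gives 1.6 nM. Compound 3 is estimated to give 300 nM in this assay, within a range of 30 nM to 3000 nM.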

Compound 3, inhibition constant: 55.5 nM
Beside the measured number, compound 3's estimate is 5.4-fold (0.73 log units) above it; the range from low to high includes it.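

No step can be read from compound 2 to compound 3: in this assay compound 3 gives 55.5 nM while compound 2 has only the report "not active". The size of the change from ((trifluoromethyl)sulfonyl)amino to methyl(methylsulfonyl)amino stays open, and no evidence on a cause is available.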